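A few compounds are considered here, and "the series" means these few. Any claim that something is new, unique, unknown or untested is made for them only; others in the source may bear on it.

Measured in a functional assay (aorta) with Rattus norvegicus as the target; a higher number here means a weaker inhibitor, a lower number a stronger inhibitor:
- Compound 1 `CC1(C)Oc2ccc(C#N)cc2[C@@H](/N=C(\NC#N)Oc2ccccc2)[C@@H]1O`: > 100000 nM (a limit of the assay, not a number)
- Compound 2 `CC1(C)Oc2ccc(C#N)cc2[C@@H](/N=C(\NC#N)Nc2ccc(N)cc2)[C@@H]1O`: 3500 nM
- Compound 3 `CC1(C)Oc2ccc(C#N)cc2[C@@H](/N=C(\NC#N)Nc2cccc([N+](=O)[O-])c2)[C@@H]1O`: 670 nM

Compound 3 has the lowest number in this small set, and its steps to both other compounds lie beyond the scatter. Compound 4 `COC(=O)c1ccc(N/C(=N/[C@@H]2c3cc(C#N)ccc3OC(C)(C)[C@H]2O)NC#N)cc1` has not yet been measured. It carries 4-(methoxycarbonyl)phenyl in place of 3-nitrophenyl on an amine nitrogen.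

The large steps, an at least 28-fold lower number from compound 1 to compound 2 (1.45 log units; beyond the scatter) and an at least 140-fold lower number from compound 1 to compound 3 (2.17 log units; beyond the scatter), both replace phenoxy with an amino-linked aryl group. Compound 4 keeps that amine nitrogen, so these steps say little about the new change. The closest guide is a 5.2-fold lower number from compound 2 to compound 3 (0.72 log units; beyond the scatter), a modest step that swaps one aryl group for another on the same nitrogen. A step of similar or smaller size is therefore expected, more likely upward since compound 3 sits lowest. That would be an expected 1.8-fold higher number from compound 3 to compound 4 (0.25 log units; within the scatter).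

For compound 4 the estimated value is 1200 nM, with an expected range from 350 nM to 4000 nM.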

Compound 4, half-maximal inhibitory concentration: 18400 nM
Beside the measured number, compound 4's estimate is 15-fold (1.19 log units) below it; measured number outside the range, above it.
By their numbers in this assay, from the lowest: compound 3; then compound 2; then compound 4. At a limit, above all of these: compound 1.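

In this assay, the aryl group on this amine nitrogen turns out to matter more than the earlier aryl swap suggested, with a large step: a 27-fold higher number from compound 3 to compound 4 (1.44 log units; beyond the scatter). Methoxycarbonyl in place of amino on an aromatic carbon moves the number the same way, though by a modest step: a 5.3-fold higher number from compound 2 to compound 4 (0.72 log units; beyond the scatter). Nothing given here explains why these changes raise the number.

As far as these compounds go, the groups 3-nitrophenyl and 4-(methoxycarbonyl)phenyl differ in both the substituent and its place on the ring, so it stays open which of the two drives the large step. Also open, from the compounds shown here alone, is where plain phenyl, 4-nitrophenyl, 3-(methoxycarbonyl)phenyl or a 4-carboxyphenyl group, which carries a carboxylic acid, would fall in this order.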